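A few compounds are considered here, and "the series" means these few. Any claim that something is new, unique, unknown or untested is made for them only; others in the source may bear on it.

Working notes on the shared core of compound 1 `O=c1cc(-n2cc(CSc3ccccc3)nn2)c2cc(Br)ccc2o1`, which in a functional assay on A549 cells (Homo sapiens) for antiproliferative activity, read by MTT assay, with a stated time of 48 h (a higher number here means a weaker inhibitor, a lower number a stronger inhibitor), gives 3510 nM. Compound 2 `O=c1cc(-n2cc(COc3ccccc3)nn2)c2cc(Br)ccc2o1` gives 12300 nM in this assay, and compound 3 `Nc1ccc(OCc2cn(-c3cc(=O)oc4ccc(Br)cc34)nn2)cc1` gives 11900 nM in this assay. Compound 3 stands second highest of the three numbers: a 1.0-fold lower number from compound 2 to compound 3 (0.01 log units; within the scatter) lies within the scatter, while a 3.4-fold higher number from compound 1 to compound 3 (0.53 log units; beyond the scatter) lies beyond it. What separates compound 1 from the other two is the group on the saturated chain carbon, seen in a 3.5-fold higher number from compound 1 to compound 2 (0.54 log units; beyond the scatter) and a 3.4-fold higher number from compound 1 to compound 3 (0.53 log units; beyond the scatter).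

Compound 4 `O=c1cc(-n2cc(COc3ccc(F)cc3)nn2)c2cc(Br)ccc2o1` differs from compound 3 by fluoro in place of amino on an aromatic carbon. The only measured step on that aromatic carbon is a 1.0-fold lower number from compound 2 to compound 3 (0.01 log units; within the scatter), which sat within the scatter, so a substituent there has so far shown nothing in this assay. The other two steps alter the group on the saturated chain carbon, not the six-membered aromatic ring, and do not bear directly on this change. No step beyond the scatter is therefore expected for compound 4 in this assay, that is a 1.0-fold higher number from compound 3 to compound 4 (0.00 log units; within the scatter). Compound 4 is estimated at 12000 nM in this assay, with a range of 5000 nM to 30000 nM.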

Compound 4, half-maximal inhibitory concentration: 850 nM
The estimate for compound 4 lay 14-fold (1.15 log units) above the measured number, and the stated range ends above it.
By their numbers in this assay, from the lowest: compound 4; then compound 1; then compounds 3 and 2 (each within the scatter of the next).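

In this assay the aromatic carbon para to a large group no longer looks silent: fluoro in place of hydrogen gives a 14-fold lower number from compound 2 to compound 4 (1.16 log units; beyond the scatter) and fluoro in place of amino gives a 14-fold lower number from compound 3 to compound 4 (1.15 log units; beyond the scatter), whereas amino in place of hydrogen gave only a 1.0-fold lower number from compound 2 to compound 3 (0.01 log units; within the scatter). What counts at this carbon is therefore which group sits there, and with fluoro the phenoxy compounds no longer trail phenylsulfanyl, since 4-fluorophenoxy in place of phenylsulfanyl gives a 4.1-fold lower number from compound 1 to compound 4 (0.62 log units; beyond the scatter). No measurement at hand accounts for fluoro and amino parting in this way.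

Going by these compounds, whether the step belongs to fluoro alone or extends to chloro, bromo, methoxy or a nitrile on this carbon stays open. Also open, on these data alone, is whether a fluoro on the phenylsulfanyl ring of compound 1 would give a similar step.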